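A few compounds are considered here, and "the series" means these few. Any claim that something is new, unique, unknown or untested is made for them only; others in the source may bear on it.

Measured compounds:
compound 1 `ClCc1ccc(Cn2cnc3c(Cl)ncnc32)cc1`, 6760 nM
compound 2 `ClCc1ccccc1Cn1cnc2c(Cl)nc(Cl)nc21`, 3630 nM

In a functional assay on HOP-62 cells (Homo sapiens) for cytotoxicity, read by sulforhodamine B assay, with a stated time of 48 h (a lower number here means a stronger inhibitor of growth, a higher number a weaker inhibitor of growth), compound 2 gives the lower of the two numbers, but compound 1 lies within the scatter of it, so no order can be read from them. Compound 3 `ClCc1ccccc1Cn1cnc2c(Cl)ncnc21` is compound 2 with hydrogen in place of chloro on an aromatic carbon. For the measured compounds named here, no measured pair shows this exact change, and compound 1 and compound 2 differ in two places, so nothing can be computed from them. The step in this assay is expected to be small, most likely within the scatter, perhaps slightly toward a higher number. Compound 3 is expected to give 5000 nM, with a range of 2000 nM to 13000 nM, a step of a 1.4-fold higher number from compound 2 to compound 3 (0.14 log units; within the scatter).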

Compound 3, concentration for total growth inhibition: 6020 nM
Compound 3: middle estimate off by 1.2-fold (0.08 log units), on the low side; the range from low to high includes it.
By their numbers in this assay, from the lowest: compounds 2, 3 and 1 (each within the scatter of the next).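

In this assay, for the compounds shown here, the chloro group on the aromatic carbon between two ring nitrogen atoms gives way to hydrogen with a 1.7-fold higher number from compound 2 to compound 3 (0.22 log units; within the scatter) as the step, the first comparison here of compounds differing in one place. At this position, then, the exchange of chloro for hydrogen gives no step beyond the scatter. Nothing available offers an explanation for this result.

The compounds shown leave open whether an amine or a methoxy group on this carbon would give a step beyond the scatter. They also leave open what replacing the remaining chloro group with an amine would do.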